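The compounds below may be only part of what the source reports. "The series", "measured", "known", "first", "only" and "open" are said of these compounds alone.

Measured so far:
- compound 1 `COc1ccccc1C1C(C#N)=C(N)N(c2ccc(S(N)(=O)=O)cc2)C2=C1CCCC2`: 50%
- compound 2 `COc1ccc(C2C(C#N)=C(N)N(c3ccc(S(N)(=O)=O)cc3)C3=C2CCCC3)cc1`: 100%

In a functional assay on Ehrlich cells (Mus musculus) for cytotoxicity, read by trypan blue exclusion, with a stated time of 2 h, tested at 50 ug/mL (a lower number here means a weaker effect, a higher number a stronger effect of the compound at the concentration tested), compound 2 gives 100%, the higher of the two numbers; compound 1 lies a number 50 percentage points higher from compound 1 to compound 2 (beyond the scatter) away. Compound 3 `N#CC1=C(N)N(c2ccc(S(N)(=O)=O)cc2)C2=C(CCCC2)C1c1ccc(Cl)cc1Cl` is not yet measured. It differs from compound 2 by 2,4-dichlorophenyl in place of 4-methoxyphenyl on a saturated ring carbon. Within the data shown here, no measured step covers a change of this kind: the only step known moves a methoxy group from one position of the phenyl ring to another, not an exchange of the group itself. The expectation therefore rests on compound 2 alone, and the step to compound 3 is estimated as a number 15 percentage points lower from compound 2 to compound 3 (beyond the scatter). Compound 3 is expected to give 85%, with a range from 50% to 100%.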

Compound 3, a percentage reported as activity, at one concentration (the size of the read-out at that concentration, not a potency): 50%
For compound 3 the middle estimate is 35 percentage points above the measured one, within the range that was stated.
By their numbers in this assay, from the lowest: compounds 1 and 3 (each within the scatter of the next); then compound 2.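

In this assay the exchange on the saturated ring carbon gives a number 50 percentage points lower from compound 2 to compound 3 (beyond the scatter) so 2,4-dichlorophenyl does not keep the level of 4-methoxyphenyl. Against 2-methoxyphenyl the same group gives no change at the digits printed from compound 1 to compound 3 (within the scatter) so of the three substituted phenyl groups only 4-methoxyphenyl stands apart. Nothing at hand accounts for this result.

Going by these compounds, whether 4-chlorophenyl or unsubstituted phenyl would read with compound 2 or with compound 3 stays open, so the contribution of each chlorine cannot be separated. On these data alone, the response to a pyridyl or a cyclohexyl group at this carbon is also open.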